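Thioglycosides in the guinea-pig T-cell proliferation assay

A few compounds are considered here, and "the series" means these few. Any claim that something is new, unique, unknown or untested is made for them only; others in the source may bear on it.

Measured so far:
compound 1 `OCC1OC(SC/C=C/c2ccccc2)C(O)C(O)C1O` — 871000 nM
compound 2 `CC1OC(SC/C=C/c2ccccc2)C(O)C(O)C1O` — 102000 nM; 160000 nM; 750000 nM; 525000 nM (4 entries)
compound 3 `CC1OC(OCC2OC(SCCCc3ccccc3)C(O)C(O)C2O)C(O)C(O)C1O` — 340000 nM

In a functional assay (T-cell) for inhibition, with Cavia porcellus as the target, read by thymidine incorporation (a lower number here means a stronger inhibitor, a higher number a weaker inhibitor), compound 3 gives the lowest of the two single numbers shown, with compound 1 the nearest at a gap beyond the scatter. Compound 2 has no single number; its repeat entries spread widely, as the record of the several entries shows (the several entries of compound 2 in this assay, 102000 nM; 160000 nM; 750000 nM; 525000 nM (4 entries)).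

The next compound, compound 4 `OCC1OC(SCCCc2ccccc2)C(O)C(O)C1O`, is to be measured in this assay. It differs from compound 3 in one place: hydrogen in place of 3,4,5-trihydroxy-6-methyloxan-2-yl on an oxygen on a saturated carbon. The compound that remains carries the same propyl-linked aryl thioglycoside as compound 3, but without the second sugar.

Within the data shown here, no step between measured compounds is available. The closest guide is compound 1, which likewise lacks the second sugar and gives 871000 nM; on that basis the step is expected to go toward a higher number, by a modest amount that may or may not clear the scatter. The value for compound 4 is therefore estimated at 650000 nM, with a range from 220000 nM to 2000000 nM, a step expected to be a 1.9-fold higher number from compound 3 to compound 4 (0.28 log units; within the scatter).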

Compound 4, half-maximal inhibitory concentration: 402000 nM
Compound 4: the middle estimate sits 1.6-fold (0.21 log units) above what was measured, within the range that was stated.
By their numbers in this assay, from the lowest: compounds 3 and 4 (each within the scatter of the next); then compound 1.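

In this assay, hydrogen in place of 3,4,5-trihydroxy-6-methyloxan-2-yl on an oxygen on a saturated carbon gives a 1.2-fold higher number from compound 3 to compound 4 (0.07 log units; within the scatter). Among these compounds, this is the first one-place comparison, and it shows that losing this whole group, with its 10 heavy atoms, leaves no difference that can be read in this assay. Any reading of small differences in the series needs caution, as repeat entries can spread far more widely than this step: the several entries of compound 2 in this assay, 102000 nM; 160000 nM; 750000 nM; 525000 nM (4 entries)

Going by these compounds, it remains open whether a smaller group on this oxygen, such as a methyl ether or an acetic acid side chain, would give a number distinct from these two. Also open, on these data alone, is whether the same exchange would leave the number unchanged on other thioglycoside chains.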